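This account rests on a few compounds, and the source may have more. Where it says the series, first, only, none or still open, it means among the compounds named here.

In a functional assay on MCF-10A cells (Homo sapiens) for antiproliferative activity, with a stated time of 48 h (a higher number here means that more compound is needed for the effect, a lower number that less compound is needed), compound 1 `COc1ccc2nc(C)cc(NCc3ccccc3)c2c1` gives 25900 nM. On the same core, compound 2 `COc1ccc2nc(C)cc(NCc3ccccc3F)c2c1` gives 14000 nM. Among the measured compounds shown here, the one measured step between them, a 1.9-fold lower number from compound 1 to compound 2 (0.27 log units; within the scatter), is fluoro in place of hydrogen on an aromatic carbon. It lies within the scatter, so compound 2 stands level with compound 1 on the two numbers available.

Compound 3 `COc1ccc2nc(C)cc(NCc3ccc(F)cc3F)c2c1` extends compound 2 by the same kind of change: fluoro in place of hydrogen on an aromatic carbon. The new fluoro sits on an aromatic carbon, meta to a fluoro group and para to a large group. For the measured compounds named here, only the step of a 1.9-fold lower number from compound 1 to compound 2 (0.27 log units; within the scatter) bears on this change, and it is a single example at a different place on the ring, with no measured step yet at this one. A small shift toward a lower number in this assay is therefore expected, but nothing clearly beyond the scatter. The expected change is a 1.3-fold lower number from compound 2 to compound 3 (0.10 log units; within the scatter). For compound 3 the estimated value is 11000 nM, with an expected range from 5000 nM to 24000 nM.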

Compound 3, half-maximal effective concentration: 11600 nM
Estimate against measurement, compound 3: 1.1-fold (0.02 log units) below, and the stated range covers the measured number.
By their numbers in this assay, from the lowest: compounds 3, 2 and 1 (each within the scatter of the next, the first and the last beyond it).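

At the aromatic carbon meta to a fluoro group and para to a large group, the change from hydrogen to fluoro now has its own measured step in this assay, (a 1.2-fold lower number from compound 2 to compound 3 (0.08 log units; within the scatter)), so this place no longer rests on a single example from elsewhere on the ring. Set beside the earlier step at the other place (a 1.9-fold lower number from compound 1 to compound 2 (0.27 log units; within the scatter)), it shows the same outcome: at both places on this ring, fluoro in place of hydrogen leaves the number within the scatter, and a second fluoro on the ring of compound 2 gives no readable shift. No supporting evidence is available that would account for this result.

The compounds shown leave open whether any group other than fluoro at this place, such as chloro, methoxy, trifluoromethyl or an amine, would move the number beyond the scatter. They also leave open whether a change outside this ring, such as a longer chain in place of the methylene link to the ring, would do so.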